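Cyclopentyl ether to cyclopentyl ester on the shared core

The compounds below may be only part of what the source reports. "The series", "measured", "known", "first", "only" and "open" are said of these compounds alone.

Measured compounds:
compound 1 `COc1ccc(C(=O)Nc2ccccc2Cl)cc1OC1CCCC1` 190 nM
compound 2 `COc1ccc(C(=O)Nc2ccccc2C)cc1OC1CCCC1` 300 nM
compound 3 `COc1ccc(C(=O)Nc2cccc(Cl)c2Cl)cc1OC1CCCC1` (limit, see below)

In an assay on isolated protein for inhibition of phosphodiesterase 4A (Sus scrofa) (on this read-out lower numbers stand for stronger inhibition and higher numbers for weaker inhibition), compound 1 gives 190 nM and compound 2 gives 300 nM; the step of a 1.6-fold higher number from compound 1 to compound 2 (0.20 log units; within the scatter) lies within the scatter. Compound 3 reaches only a limit of this assay, > 200000 nM, and the limit of > 200000 nM in this assay, at which 1 of the 3 values shown sits, marks that limit. The step of an at least 1000-fold higher number from compound 1 to compound 3 (3.02 log units; beyond the scatter) and the step of an at least 660-fold higher number from compound 2 to compound 3 (2.82 log units; beyond the scatter) are both large. Compound 1 thus holds the lowest of the two numbers shown, with compound 2 nearest.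

Compound 4 `COc1ccc(C(=O)Nc2ccccc2Cl)cc1OC(=O)C1CCCC1` keeps the aniline of compound 1 and changes the other side: cyclopentylcarbonyl in place of cyclopentyl on an oxygen on an aromatic ring. For the measured compounds named here, all measured steps concern the substituents on the aniline; none of them touches the oxygen on the aromatic ring, so no measured step bears directly on this change. Any expectation for compound 4 in this assay therefore rests on the core alone and carries a wide range. Compound 4 is estimated at 2000 nM (range 200 nM to 20000 nM), a step of an 11-fold higher number from compound 1 to compound 4 (1.02 log units; beyond the scatter) expected from compound 1.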

Compound 4, half-maximal inhibitory concentration: > 1000000 nM
Compound 4 was reported as a limit; the forecaster's own chance of this, stated with the estimate: 10%; middle value at least 500-fold (2.69 log units) from the limit.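

For the compounds shown here, the oxygen on the aromatic ring is the first place changed away from the aniline, and it proves at least as sensitive: an at least 5200-fold higher number from compound 1 to compound 4 (3.72 log units; beyond the scatter). With the aniline of compound 1 held fixed, cyclopentylcarbonyl in place of cyclopentyl on this oxygen is therefore not tolerated in this assay, so large steps are not confined to the aniline substituents. Compound 4 gives no number, only a limit of the assay, and that limit says nothing of the cause: the limit of > 1000000 nM in this assay, at which 1 of the 4 values shown sits.

This single pair does not separate the entering carbonyl from the two extra heavy atoms of the larger group; a cyclopentylmethyl group on the same oxygen would bear on that. From the compounds shown here alone, whether the same change behaves alike with the 2-methylphenyl group of compound 2 also remains open.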